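Lengthening the Side Chain: Isopropyl Replaced by Pentyl

A few compounds are considered here, and "the series" means these few. Any claim that something is new, unique, unknown or untested is made for them only; others in the source may bear on it.

Within the data shown here, compound 1 `COC(=O)C#CC(CC(C)C)O/C=C/C(=O)OC` carries the only measured number in this set. In a functional assay on SW1573 cells (Homo sapiens) for antiproliferative activity, read by sulforhodamine B assay, with a stated time of 48 h (a lower number here means a stronger inhibitor of growth, a higher number a weaker inhibitor of growth), compound 1 gives 380 nM. Compound 2 `CC1CCC(C(C)C)C(OC(=O)C#CC(O/C=C/C(=O)OC2CC(C)CCC2C(C)C)C(C)C)C1` gives only a limit of the assay in this assay, > 100000 nM. That value is the limit of > 100000 nM in this assay, at which 1 of the 2 values shown sits. Compound 3 `CCCCCCC(C#CC(=O)OC)O/C=C/C(=O)OC` differs from compound 1 in a single place: pentyl in place of isopropyl on a saturated chain carbon, two bonds along the chain from an oxygen on an unsaturated carbon and a triple-bonded carbon. Among the measured compounds shown here, no measured pair shows this particular change, so the step cannot be read from the data. The step of a 1.3-fold lower number from compound 1 to compound 3 (0.10 log units; within the scatter) is expected to be small, none beyond the scatter. Compound 3 is therefore estimated at 300 nM, with a likely range from 100 nM to 1000 nM.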

Compound 3, concentration for 50% growth inhibition: 3300 nM
Estimate against measurement, compound 3: 11-fold (1.04 log units) below; measured number above the stated range.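

Pentyl in place of isopropyl at this saturated chain carbon is not a neutral swap: in this assay, the change gives an 8.7-fold higher number from compound 1 to compound 3 (0.94 log units; beyond the scatter). This single pair shows that growth inhibition responds to the side chain at this position, and that here the larger group is the weaker one. Nothing shown explains why the number rises.

From the compounds shown here alone, whether the loss grows steadily with chain length remains open. So does how a shorter methyl group, a cyclohexyl ring or an amine on the chain would behave at this carbon.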